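Working notes: chloro in place of bromo

The compounds below may be only part of what the source reports. "The series", "measured", "known", "first", "only" and "open" are said of these compounds alone.

Values from a physicochemical assay for solubility, read by spectrophotometry, in phosphate buffer, with a stated time of 18 h, at pH 7.4 (on this read-out lower numbers stand for lower solubility and higher numbers for higher solubility), as measured so far:
- compound 1 `CCc1ccc(-c2nc3c(c(C)nn3-c3ccccc3)c(-c3ccccc3[N+](=O)[O-])c2C#N)cc1` gives 1200 nM
- compound 2 `CCc1ccc(-c2nc3c(c(C)nn3-c3ccccc3)c(-c3ccccc3I)c2C#N)cc1` gives 8500 nM
- compound 3 `CCc1ccc(-c2nc3c(c(C)nn3-c3ccccc3)c(-c3ccccc3Br)c2C#N)cc1` gives 1500 nM

Compound 3, the 2-bromophenyl member, sits with compound 1 at the low end of these numbers: the data show a 1.3-fold higher number from compound 1 to compound 3 (0.10 log units; within the scatter), against a 5.7-fold lower number from compound 2 to compound 3 (0.75 log units; beyond the scatter). Compound 2 stands apart from both, with a 7.1-fold higher number from compound 1 to compound 2 (0.85 log units; beyond the scatter).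

The unmeasured compound 4 `CCc1ccc(-c2nc3c(c(C)nn3-c3ccccc3)c(-c3ccccc3Cl)c2C#N)cc1` is the 2-chlorophenyl analogue. The change is chloro in place of bromo on an aromatic carbon, on an aromatic carbon, ortho to a large group.

Within the data shown here, the one measured swap of halogens is a 5.7-fold lower number from compound 2 to compound 3 (0.75 log units; beyond the scatter). A single step fixes no trend across halogens, and chloro itself has not been measured in this series. No step beyond the scatter is therefore expected in this assay, with a slight lean towards lower numbers. For compound 4 the estimated value is 1400 nM, with an expected range from 600 nM to 3500 nM. The estimate means an expected 1.1-fold lower number from compound 3 to compound 4 (0.03 log units; within the scatter).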

Compound 4, solubility: 1700 nM
The estimate for compound 4 lay 1.2-fold (0.08 log units) below the measured number; the range from low to high includes it.
By their numbers in this assay, from the lowest: compounds 1, 3 and 4 (each within the scatter of the next); then compound 2.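

In this assay, among these compounds, the first swap between two lighter halogens at this position, ortho to a large group, gives (a 1.1-fold higher number from compound 3 to compound 4 (0.05 log units; within the scatter)), so 2-chlorophenyl and 2-bromophenyl cannot be told apart here. Chloro also matches nitro (a 1.4-fold higher number from compound 1 to compound 4 (0.15 log units; within the scatter)), while the iodo member stays separate (a 5.0-fold lower number from compound 2 to compound 4 (0.70 log units; beyond the scatter)), which leaves iodo as the only one of the four groups whose number stands apart from the others. Nothing at hand explains why iodo alone stands apart.

The compounds shown leave open whether fluoro, methoxy or an amine on this same carbon would group with chloro, bromo and nitro or with iodo. They also leave open whether the separation of iodo would hold on a different core.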